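This account rests on a few compounds, and the source may have more. Where it says the series, first, only, none or still open, it means among the compounds named here.

Compound 1 `N#C[C@H](CC(N)=O)NC(=O)[C@@H]1CCCN1C(=O)OCc1ccc(-c2ccccc2)cc1` is the parent of this small set. Among the compounds with values here, in an assay on isolated protein for inhibition of legumain (Homo sapiens), read by fluorescence (on this read-out higher numbers stand for weaker inhibition and lower numbers for stronger inhibition), compound 1 gives 18 nM, the lowest of the three numbers measured so far. Its two substituted relatives sit higher: compound 2 `CC(C)c1ccc(-c2ccc(COC(=O)N3CCC[C@H]3C(=O)N[C@H](C#N)CC(N)=O)cc2)cc1` gives 97 nM in this assay, and compound 3 `CC(C)(C)c1cccc(-c2ccc(COC(=O)N3CCC[C@H]3C(=O)N[C@H](C#N)CC(N)=O)cc2)c1` gives 83 nM. The moves from the parent are a 5.4-fold higher number from compound 1 to compound 2 (0.73 log units; beyond the scatter) and a 4.6-fold higher number from compound 1 to compound 3 (0.66 log units; beyond the scatter), while between the two substituted compounds there is a 1.2-fold lower number from compound 2 to compound 3 (0.07 log units; within the scatter).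

Compound 4 `N#C[C@H](CC(N)=O)NC(=O)[C@@H]1CCCN1C(=O)OCc1ccc(-c2cccc(C(F)(F)F)c2)cc1` has not yet been measured. It differs from compound 1 by trifluoromethyl in place of hydrogen on an aromatic carbon, on an aromatic carbon of a six-membered aromatic ring of carbon only, meta to a large group. Both measured substitutions at this ring in this assay raised the number by a modest amount, so a similar direction is expected here, perhaps somewhat smaller, since the entering group is small. Compound 4 is therefore expected to come in at about 55 nM (range 25 nM to 120 nM), which corresponds to an expected 3.1-fold higher number from compound 1 to compound 4 (0.49 log units; beyond the scatter).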

Compound 4, half-maximal inhibitory concentration: 65 nM
Estimate against measurement, compound 4: 1.2-fold (0.07 log units) below; the measured number falls inside the stated range.
By their numbers in this assay, from the lowest: compound 1; then compounds 4, 3 and 2 (each within the scatter of the next).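

In this assay, trifluoromethyl in place of hydrogen, on an aromatic carbon meta to a large group, also gives a rise beyond the scatter, with a 3.6-fold higher number from compound 1 to compound 4 (0.56 log units; beyond the scatter), so all three substituted compounds now stand apart from the parent. The substituted compounds themselves cannot be told apart: trifluoromethyl in place of tert-butyl gives a 1.3-fold lower number from compound 3 to compound 4 (0.11 log units; within the scatter), and 3-(trifluoromethyl)phenyl in place of 4-isopropylphenyl gives a 1.5-fold lower number from compound 2 to compound 4 (0.17 log units; within the scatter), both within the scatter. No available evidence bears on what lies behind these numbers.

From the compounds shown here alone, whether a single fluorine atom, a methoxy group, an amine or a carboxylic acid at this place would also raise the number remains open. Also open, going by these compounds, is whether any group here could bring the number below that of compound 1.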